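The source may report more compounds than this note shows. Statements on the series, on what has been measured and on what is new or still open speak of the compounds shown alone.

Of the compounds shown here, three with a shared core have been tested so far in a functional assay on A549 cells (Homo sapiens) for cytotoxicity, read by MTT assay, with a stated time of 72 h; a lower number here means a stronger inhibitor, a higher number a weaker inhibitor. Compound 1 (`Cc1ccc(C(=O)Nc2nnc(-c3ccc(O)c(O)c3)s2)cc1`) gives 11800 nM here, compound 2 (`O=C(COc1ccccc1)Nc1nnc(-c2ccc(O)c(O)c2)s1`) gives 21200 nM and compound 3 (`O=C(Nc1nnc(-c2ccc(O)c(O)c2)s1)c1ccc(Cl)cc1`) gives 14600 nM in the same test. Compound 3 thus sits level with the other two, with every gap among them inside the scatter. Compound 4 (`O=C(Nc1nnc(-c2ccc(O)c(O)c2)s1)c1ccccc1`) has not yet been measured. It carries hydrogen in place of chloro on an aromatic carbon and is otherwise the same as compound 3. The closest evidence comes from the same place on the ring, where chloro in place of methyl gave a 1.2-fold higher number from compound 1 to compound 3 (0.09 log units; within the scatter) and stayed within the scatter. Larger replacements on the carbonyl carbon gave a 1.8-fold higher number from compound 1 to compound 2 (0.25 log units; within the scatter) and a 1.5-fold lower number from compound 2 to compound 3 (0.16 log units; within the scatter) and also stayed within it. Among the compounds with values here, no compound with hydrogen at that place has a measured value yet. In this assay the expected result is therefore a 1.0-fold higher number from compound 3 to compound 4 (0.01 log units; within the scatter) and no step beyond the scatter. For compound 4 the estimated value is 15000 nM (expected range 8000 nM to 28000 nM).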

Compound 4, half-maximal inhibitory concentration: 13000 nM
Compound 4: the middle estimate sits 1.2-fold (0.06 log units) above what was measured, within the range that was stated.
By their numbers in this assay, from the lowest: compounds 1, 4, 3 and 2 (each within the scatter of the next).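

In this assay, taking the chloro off this place, para to a large group, gives a 1.1-fold lower number from compound 3 to compound 4 (0.05 log units; within the scatter) for hydrogen in place of chloro, and the comparison with methyl at the same place gives a 1.1-fold higher number from compound 1 to compound 4 (0.04 log units; within the scatter) for hydrogen in place of methyl, so hydrogen, chloro and methyl now all read as level there and the ring needs no group at this place to hold that level. On the carbonyl carbon, the plain phenyl also stays level with phenoxymethyl, with a 1.6-fold lower number from compound 2 to compound 4 (0.21 log units; within the scatter) for that exchange. Nothing shown gives a reason for these steps.

Within the data shown here, what the compounds leave open is whether any group moves this number beyond the scatter, since no step so far does. An amine or a carboxylic acid at this place on the ring, or a longer chain on the carbonyl carbon, would be the next test of that.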